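Swapping methyl for chloro on the aryl ketone of compound 1

The source may hold more compounds than are shown below. What is called first, only, known or untested is meant among the compounds shown, and "the series" means these compounds.

Measured compounds:
compound 1 `COc1cc(-c2nnc3n2NC(c2cccs2)C(C(=O)c2ccc(C)cc2)S3)cc(OC)c1OC` — 28400 nM
compound 2 `COc1cc(-c2nnc3n2NC(c2ccco2)C(C(=O)c2ccc(C)cc2)S3)cc(OC)c1OC` — > 100000 nM
compound 3 `COc1cc(-c2nnc3n2NC(c2ccco2)C(C(=O)c2ccc(F)c(F)c2)S3)cc(OC)c1OC` — 73200 nM

Three compounds share one core and were tested in a functional assay on MCF7 cells (Homo sapiens) for cytotoxicity, read by MTT assay, with a stated time of 48 h; a lower number here means a stronger inhibitor, a higher number a weaker inhibitor. Compound 1 gives 28400 nM and is the lowest of the two numbers; its nearest neighbour, compound 3, gives 73200 nM. Compound 2 reaches only the limit (the limit of > 100000 nM in this assay, at which 1 of the 3 values shown sits), so its result is a limit, not a number. Compound 4 `COc1cc(-c2nnc3n2NC(c2cccs2)C(C(=O)c2ccc(Cl)cc2)S3)cc(OC)c1OC` is not yet measured. It differs from compound 1 in one place: chloro in place of methyl on an aromatic carbon.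

Two measured steps set the scale. Changing the ring on the saturated carbon gave an at least 3.5-fold higher number from compound 1 to compound 2 (0.54 log units; beyond the scatter). Changing the ring on the carbonyl carbon, the place touched here, gave an at least 1.3-fold lower number from compound 2 to compound 3 (0.13 log units; that floor lies within the scatter). Among the compounds with values here, that second step is the one that bears on compound 4, and its floor lies within the scatter, so a change at this position looks small. A step of about a 1.1-fold lower number from compound 1 to compound 4 (0.06 log units; within the scatter) is therefore expected, none beyond the scatter. Compound 4 is estimated at 25000 nM, between 9000 nM and 70000 nM.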

Compound 4, half-maximal inhibitory concentration: 42800 nM
For compound 4 the middle estimate is 1.7-fold (0.23 log units) below the measured one; the range from low to high includes it.
By their numbers in this assay, from the lowest: compounds 1, 4 and 3 (each within the scatter of the next, the first and the last beyond it). At a limit, above all of these: compound 2.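

Chloro in place of methyl on the aryl ketone gives a 1.5-fold higher number from compound 1 to compound 4 (0.18 log units; within the scatter), so this swap does not separate the two compounds. Compound 2, the starting point of the earlier step on this aryl ketone, stands at a limit and not a number, so that step gave only a floor: the limit of > 100000 nM in this assay, at which 1 of the 4 values shown sits. The new step has a real number at both ends, and it shows that, with the thiophen-2-yl ring held fixed, this position accepts chloro in place of methyl without a change beyond the scatter.

As far as these compounds go, whether an amine, a carboxylic acid or a longer chain in this same spot would move the number remains open. Also open, from the compounds shown here alone, is whether the 4-chlorophenyl ketone would behave the same way alongside the furan-2-yl ring.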